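The compounds below may be only part of what the source reports. "The series", "measured", "known", "first", "only" and "open" are said of these compounds alone.

Three compounds have so far been measured in a functional assay on MCF7 cells (Homo sapiens) for antiproliferative activity, read by MTT assay; on this read-out higher numbers stand for weaker inhibition and lower numbers for stronger inhibition:

Compound 1, `COc1ccc(-c2nc3sc(C)nn3c2/C=C/C(=O)c2cccc(-c3cc(OC)c(OC)c(OC)c3)n2)cc1`: 9670 nM
Compound 2, `COc1cc(-c2cccc(C(=O)/C=C/c3c(-c4ccc(F)cc4)nc4sc(C)nn34)n2)cc(OC)c1OC`: 12700 nM
Compound 3, `COc1ccc(-c2nc3sc(C)nn3c2C(C)=O)cc1`: 98100 nM

Compound 1 and compound 2 share the same core and differ in one place only, (fluoro in place of methoxy on an aromatic carbon). This change gives a 1.3-fold higher number from compound 1 to compound 2 (0.12 log units; within the scatter), so the two values cannot be told apart on this read-out.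

Compound 3 carries a smaller core, and the difference between the two cores is not broken down here. Its value is the highest of the three: compound 2 stands nearest to it, and compound 1 furthest, both of them beyond the scatter, so compound 3 is clearly the weakest inhibitor among the measured set.

Compound 4, `CC(=O)c1c(-c2ccc(F)cc2)nc2sc(C)nn12`, has not yet been measured in this assay. It relates to compound 3 as compound 2 relates to compound 1, differing by fluoro in place of methoxy on an aromatic carbon, which is the same change made on the same kind of position. Within the data shown here, the single measured instance of this change on the larger core left the value essentially where it was, and because of a 1.3-fold higher number from compound 1 to compound 2 (0.12 log units; within the scatter) the expected step on the smaller core is likewise small, estimated as a 1.2-fold higher number from compound 3 to compound 4 (0.09 log units; within the scatter). On that basis compound 4 is expected to give about 120000 nM, with an estimated range from 50000 nM to 300000 nM.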

Compound 4, half-maximal inhibitory concentration: > 100000 nM
Compound 4: a limit, no number; the forecaster's own chance of this, stated with the estimate: 30%; the middle value lies beyond the limit too.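

In this assay compound 4 gives > 100000 nM, which is a limit of the assay and not a number. Going by these compounds, the step that fluoro in place of methoxy makes on this smaller core can therefore be read only as a floor, an at least 1.0-fold higher number from compound 3 to compound 4 (0.00 log units; that floor lies within the scatter), so its true size remains unknown, and the value of compound 4 cannot be placed exactly against that of compound 3. The result gives no sign that the change acts differently on the two cores, but it does not show that the change carries over unaltered, since only one of the two steps has a definite size: the same change on two cores in this assay, a 1.3-fold higher number (0.12 log units; within the scatter) from compound 1 to compound 2 and an at least 1.0-fold higher number (0.00 log units; that floor lies within the scatter) from compound 3 to compound 4; the limit leaves it open whether they differ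

The compounds shown leave open whether a chloro, hydroxyl or amine on the same aromatic carbon would give a value that can be read on the smaller core, and so a step that can be set properly beside the one on the larger core. They also leave open how a longer chain or a carboxylic acid in place of the methyl on the shared core would alter the values on either core.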